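The source may report more compounds than this note shows. Statements on the series, on what has been measured and on what is new or still open speak of the compounds shown alone.

The measured compounds:
Compound 1 `O=C(Nc1ccc(Sc2nc3ccccc3s2)c(Cl)c1)c1cccc(Br)c1O`: in an assay on isolated protein for inhibition of thiosulfate sulfurtransferase (Homo sapiens), with a stated time of 60 min, in the absence of a further agent (on this read-out lower numbers stand for stronger inhibition and higher numbers for weaker inhibition), compound 1 gives > 100000 nM, which is a limit of the assay.
Compound 2 `COc1c(Br)cc(Br)cc1C(=O)Nc1ccc(Sc2nc3ccccc3s2)c(Cl)c1`: in this assay compound 2 gives > 100000 nM, again a limit.
Compound 3 `COc1c(Br)cc(Br)cc1C(=O)Nc1cccc(Cl)c1`: in this assay compound 3 gives > 100000 nM, again a limit.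

Compound 2 thus stands only at a limit in this assay, and the limit of > 100000 nM in this assay, at which 3 of the 3 values shown sit, holds for every value shown. Compound 4 `O=C(Nc1ccc(Sc2nc3ccccc3s2)c(Cl)c1)c1cc(Br)cc(Br)c1O` differs from compound 2 by hydrogen in place of methyl on an oxygen on an aromatic ring; read one bond further out, the difference is methoxy to hydroxy. For the measured compounds named here, two measured steps touch compound 2: a step that the two limits leave unreadable from compound 1 to compound 2 and a step that the two limits leave unreadable from compound 2 to compound 3. Neither can be read. Compound 1, which carries hydroxy rather than methoxy, sits at a limit as well, which leaves the methyl-to-hydrogen change on this oxygen unread too. The step that the limit leaves unreadable from compound 2 to compound 4 is therefore expected to be small. Compound 4 is expected to remain around the limit in this assay, at an estimated 150000 nM, within 30000 nM to 1000000 nM.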

Compound 4, half-maximal inhibitory concentration: > 100000 nM
Compound 4: a limit, no number; the forecaster's own chance of this, stated with the estimate: 80%; the middle value is on the limit's open side.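

In this assay compound 4 gives > 100000 nM, which is a limit and not a number, and neither its step from compound 1 nor its step from compound 2 can be read. The compounds shown leave open whether any of these changes alters inhibition, as all share one value: the limit of > 100000 nM in this assay, at which 4 of the 4 values shown sit.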